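This account rests on a few compounds, and the source may have more. Where it says the series, first, only, none or still open, it means among the compounds named here.

Working notes on the series, read in a functional assay on NCI/ADR-RES cells (Homo sapiens) for inhibition, read by sulforhodamine B assay, with a stated time of 48 h; on this read-out lower numbers stand for stronger inhibition of growth and higher numbers for weaker inhibition of growth. Within the data shown here, compound 1 (`O=C(Nc1cccc(-n2cc(-c3ccncc3)c(-c3ccc(Cl)c(O)c3)n2)c1)Nc1cccc(C(F)(F)F)c1`) gives 2140 nM, the highest of the three numbers so far. Compound 3 (`COc1cc(-c2nn(-c3cccc(NC(=O)c4cccc(C(F)(F)F)c4)c3)cc2-c2ccncc2)ccc1Cl`) gives 1090 nM, within the scatter of compound 1. Compound 2 (`COc1cc(-c2nn(-c3cccc(NC(=O)Nc4cc(C(F)(F)F)cc(C(F)(F)F)c4)c3)cc2-c2ccncc2)ccc1Cl`) gives 1010 nM, a lower number than compound 1 by a margin just beyond the scatter, and within the scatter of compound 3. Among the measured compounds shown here, no pair of measured compounds differs in one place only, so no measured step guides the next one. Compound 4 (`O=C(Nc1cccc(-n2cc(-c3ccncc3)c(-c3ccc(Cl)c(O)c3)n2)c1)Nc1ccc(Cl)c(Cl)c1`) carries 3,4-dichlorophenyl in place of 3-(trifluoromethyl)phenyl on an amide-type nitrogen of compound 1: 3,4-dichlorophenyl in place of 3-(trifluoromethyl)phenyl on an amide-type nitrogen. No change beyond the scatter is expected in this assay, in either direction. The expected step is small, a 1.2-fold lower number from compound 1 to compound 4 (0.08 log units; within the scatter). For compound 4 the estimated value is 1800 nM, with an expected range of 700 nM to 4500 nM.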

Compound 4, concentration for 50% growth inhibition: 2740 nM
For compound 4 the middle estimate is 1.5-fold (0.18 log units) below the measured one; measured number inside the range.
By their numbers in this assay, from the lowest: compounds 2, 3, 1 and 4 (each within the scatter of the next, the first and the last beyond it).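

Setting 3,4-dichlorophenyl in place of 3-(trifluoromethyl)phenyl on an amide-type nitrogen gives a 1.3-fold higher number from compound 1 to compound 4 (0.11 log units; within the scatter) in this assay and is the first step that can be read in this series. At this position the two substituted phenyl groups cannot be told apart on this read-out, so this change neither gains nor loses growth inhibition beyond the scatter. Nothing at hand bears on the reason for this.

As far as these compounds go, whether a non-phenyl group on this nitrogen, such as a morpholine or a short alkyl chain, would shift the number stays open. So does the effect of a basic amine or a carboxylic acid on the phenyl ring.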